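A trifluoromethyl group added to a highly soluble compound

A few compounds are considered here, and "the series" means these few. Any claim that something is new, unique, unknown or untested is made for them only; others in the source may bear on it.

Measured in a physicochemical assay for solubility, read by HPLC, at pH 7.4; a lower number here means a less soluble compound, a higher number a more soluble compound:
compound 1 `CCCCCCCc1cc(=O)c2cc(C(F)(F)F)ccc2[nH]1`: < 5000 nM (a limit)
compound 2 `CCCCCOCc1cc(=O)c2ccccc2[nH]1`: > 200000 nM (a limit)

Compound 2 stands at the limit of > 200000 nM in this assay, at which 1 of the 2 values shown sits. Compound 3 `CCCCCOCc1cc(=O)c2cc(C(F)(F)F)ccc2[nH]1` differs from it by trifluoromethyl in place of hydrogen on an aromatic carbon. For the measured compounds named here, no measured pair shows this change alone. Compound 1 also carries trifluoromethyl, on a different chain, and sits at the limit < 5000 nM. On this single comparison, a fall beyond the usual scatter is expected in this assay, with an estimated at least 6.6-fold lower number from compound 2 to compound 3 (0.82 log units; beyond the scatter). Compound 3 is estimated at 30000 nM, with an expected range of 6000 nM to 120000 nM.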

Compound 3, solubility: 15000 nM
The estimate for compound 3 lay 2.0-fold (0.30 log units) above the measured number, and the stated range covers the measured number.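

In this assay, for the compounds shown here, trifluoromethyl in place of hydrogen on this aromatic carbon gives an at least 13-fold lower number from compound 2 to compound 3 (1.12 log units; beyond the scatter), the first direct reading of this change at this position. With trifluoromethyl kept in place, pentyloxy in place of hexyl on the saturated chain carbon bound to an aromatic carbon gives an at least 3.0-fold higher number from compound 1 to compound 3 (0.47 log units; beyond the scatter), so the chain still matters on this core. The values of compound 1 and compound 2 are limits of the assay, not numbers.

On these data alone, whether a chlorine or a nitrile at this aromatic carbon would give a similar fall remains open. So does the effect of an amine on the chain of compound 3.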